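Adding a Second Fluorine to the Aryl Ether

A few compounds are considered here, and "the series" means these few. Any claim that something is new, unique, unknown or untested is made for them only; others in the source may bear on it.

Of the compounds shown here, three sharing one core have been measured in a functional assay on HepG2 cells (Homo sapiens) for antiproliferative activity, read by MTT assay, with a stated time of 72 h; a lower number here means a stronger inhibitor, a higher number a weaker inhibitor. Compound 1 `Cc1nn(C)c(Oc2cccc(F)c2)c1/C=N\CCCCCOc1cc2oc(=O)cc(C)c2cc1Cl` gives 13400 nM. Compound 3 `Cc1nn(C)c(Oc2ccc(F)cc2)c1/C=N\CCCCCCOc1cc2oc(=O)cc(C)c2cc1Cl` gives 12500 nM, the lower of the two numbers, though its gap to compound 1 lies within the usual scatter. Compound 2 `Cc1nn(C)c(Oc2ccccc2F)c1/C=N\CCCCCCOc1cc2oc(=O)cc(C)c2cc1Cl` reaches only the limit of the assay, > 25000 nM, so no number is known for it. The single one-place step among these, an at least 2.0-fold lower number from compound 2 to compound 3 (0.30 log units; that floor lies within the scatter), can only be read down to a floor that itself lies within the scatter.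

Compound 4 `Cc1nn(C)c(Oc2ccc(F)cc2F)c1/C=N\CCCCCCOc1cc2oc(=O)cc(C)c2cc1Cl` is compound 3 with fluoro in place of hydrogen on an aromatic carbon. It thereby carries the fluorine positions of compound 2 and of compound 3 together. Going by the values given here, the one measured step that moves a fluorine on this ring sets no direction beyond the scatter, so no change beyond the scatter is expected in this assay . Compound 4 is therefore estimated at 14000 nM, within 6000 nM to 30000 nM. The expected step of a 1.1-fold higher number from compound 3 to compound 4 (0.05 log units; within the scatter) is thus estimated to stay within the scatter.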

Compound 4, half-maximal inhibitory concentration: > 25000 nM
Compound 4: only a limit was reported; the forecaster's own chance of this, stated with the estimate: 25%; at least 1.7-fold (0.25 log units) between middle value and limit.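

In this assay compound 4 gives > 25000 nM, which is a limit of the assay and not a number. Changing 4-fluorophenyl to 2,4-difluorophenyl brings an at least 2.0-fold higher number from compound 3 to compound 4 (0.30 log units; that floor lies within the scatter), so this second fluoro gives no sign of a stronger inhibitor, although the size of the change cannot be read beyond that floor. Compound 2 and compound 4 both carry fluoro on the aromatic carbon ortho to the large group and both end at a limit, so the step between them cannot be read.

As far as these compounds go, how weak these two compounds really are stays open, since the measurements stop at a shared ceiling: the limit of > 25000 nM in this assay, at which 2 of the 4 values shown sit. Also open is whether chloro, methoxy or an amine on this same carbon would give a measurable number.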